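Fluoro in Place of Nitro After Three Limits

The source may hold more compounds than are shown below. What is called first, only, known or untested is meant among the compounds shown, and "the series" means these compounds.

Compound 1 `CCOC(=O)c1c(C)[nH]c(=O)c(C#N)c1-c1ccc(C)cc1` gives > 100000 nM in a functional assay on SK-OV-3 cells (Homo sapiens) for inhibition, read by MTT assay, with a stated time of 24 h (a higher number here means a weaker inhibitor, a lower number a stronger inhibitor), a limit rather than a number.
Compound 2 `CCOC(=O)c1c(C)[nH]c(=O)c(C#N)c1-c1ccc(OC)cc1` gives > 100000 nM in this assay, again a limit.
Compound 3 `CCOC(=O)c1c(C)[nH]c(=O)c(C#N)c1-c1ccc([N+](=O)[O-])cc1` gives > 100000 nM in this assay, also a limit.

All three measured compounds share one core and differ only in the group on the outer aromatic ring. Compound 3 stands exactly where the other two stand, at the limit of > 100000 nM in this assay, at which 3 of the 3 values shown sit, so no number is known for any of them. The steps among them are accordingly unreadable: a step that the two limits leave unreadable from compound 1 to compound 2, a step that the two limits leave unreadable from compound 1 to compound 3 and a step that the two limits leave unreadable from compound 2 to compound 3.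

Compound 4 `CCOC(=O)c1c(C)[nH]c(=O)c(C#N)c1-c1ccc(F)cc1` differs from compound 3 by fluoro in place of nitro on an aromatic carbon. Going by the values given here, none of the measured steps can give the size or direction of this change, as each sits between two limits. With every measured neighbour at the same limit, compound 4 is expected to be reported at that limit too, and the expected step that the limit leaves unreadable from compound 3 to compound 4 is none beyond the scatter. Compound 4 is therefore estimated at 150000 nM, with a range from 50000 nM to 500000 nM, most probably again as a limit.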

Compound 4, half-maximal inhibitory concentration: > 100000 nM
Compound 4: no number, only a limit (the forecaster's own chance of this, stated with the estimate: 85%); the middle value is on the limit's open side.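

Compound 4 is also reported only as a limit, so the steps to it from compound 1, compound 2 and compound 3 cannot be read: the limit of > 100000 nM in this assay, at which 4 of the 4 values shown sit. In this assay the compounds shown leave open whether any group on the outer aromatic ring gives a readable number.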